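The source may report more compounds than this note shows. Statements on the series, on what has been measured and on what is new or still open speak of the compounds shown alone.

Measured so far in an assay on HEK cells for antagonist activity at transient receptor potential cation channel subfamily V member 1 (Homo sapiens), read by FLIPR; on this read-out higher numbers stand for weaker inhibition and lower numbers for stronger inhibition: compound 1 `O=C(NCc1ccc(C(F)(F)F)nc1N1CCCC1)Nc1cccc2[nH]c(=O)ccc12` gives 0.94 nM; compound 2 `CCCN(CCC)c1nc(C(F)(F)F)ccc1CNC(=O)Nc1cccc2[nH]c(=O)ccc12` gives 5.21 nM; compound 3 `CCCCCCOc1nc(C(F)(F)F)ccc1CNC(=O)Nc1cccc2[nH]c(=O)ccc12` gives 3.19 nM.

Compound 3 stands second highest of the three numbers; its nearest neighbour is compound 2, within the scatter (a 1.6-fold lower number from compound 2 to compound 3 (0.21 log units; within the scatter)), and its furthest is compound 1 (a 3.4-fold higher number from compound 1 to compound 3 (0.53 log units; beyond the scatter)).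

Compound 4 `O=C(NCc1ccc(C(F)(F)F)nc1SC1CCCCC1)Nc1cccc2[nH]c(=O)ccc12` has not been measured. It differs from compound 3 in one place: cyclohexylsulfanyl in place of hexyloxy on an aromatic carbon. Within the data shown here, the steps that bear on this position are a 5.5-fold higher number from compound 1 to compound 2 (0.74 log units; beyond the scatter), a 3.4-fold higher number from compound 1 to compound 3 (0.53 log units; beyond the scatter) and a 1.6-fold lower number from compound 2 to compound 3 (0.21 log units; within the scatter). Both exchanges of pyrrolidin-1-yl for an acyclic group gave modest increases in the number, while the exchange of dipropylamino for hexyloxy stayed within the scatter. A cyclohexylsulfanyl group of the same heavy-atom count as hexyloxy is therefore expected to give a step in this assay of about a 1.4-fold higher number from compound 3 to compound 4 (0.15 log units; within the scatter), most likely within the scatter, with a slight lean towards a higher number. For compound 4 the expected value is 4.5 nM, with a range from 1.5 nM to 14 nM.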

Compound 4, half-maximal inhibitory concentration: 2.15 nM
Estimate against measurement, compound 4: 2.1-fold (0.32 log units) above, within the range that was stated.
By their numbers in this assay, from the lowest: compound 1; then compounds 4, 3 and 2 (each within the scatter of the next, the first and the last beyond it).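

In this assay, the change from hexyloxy to cyclohexylsulfanyl on this aromatic carbon next to the ring nitrogen stays within the scatter (a 1.5-fold lower number from compound 3 to compound 4 (0.17 log units; within the scatter)), so exchanging oxygen for sulfur and an open chain for a six-membered carbon ring together leaves the two compounds unseparated. Among these compounds, compound 4 is separated from both amino-substituted compounds, by modest steps beyond the scatter in opposite directions (a 2.4-fold lower number from compound 2 to compound 4 (0.38 log units; beyond the scatter); a 2.3-fold higher number from compound 1 to compound 4 (0.36 log units; beyond the scatter)), and pyrrolidin-1-yl remains the only group here whose steps to all three others lie beyond the scatter. Nothing at hand accounts for these differences.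

Compound 4 alters the linking atom and the ring at once, and their separate contributions cannot be read from it. Hexylsulfanyl and cyclohexyloxy would divide the two changes, while piperidin-1-yl or methoxy would test how far this position tolerates a different ring size or a much shorter chain.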